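Swapping 2,4-difluorophenyl for 2,6-difluorophenyl

A few compounds are considered here, and "the series" means these few. Any claim that something is new, unique, unknown or untested is made for them only; others in the source may bear on it.

Among the compounds with values here, in a functional assay on HepG2 cells (Homo sapiens) for antiproliferative activity, read by MTT assay, with a stated time of 48 h (on this read-out lower numbers stand for stronger inhibition and higher numbers for weaker inhibition), three compounds with a shared core have numbers so far. Compound 1 (`Clc1ccccc1CSc1nnc(-c2cnccn2)n1-c1ccccc1`) gives 18800 nM in this test and compound 2 (`Clc1ccc(CSc2nnc(-c3cnccn3)n2-c2ccccc2)cc1`) gives 15300 nM in the same test. Compound 3 (`Fc1ccc(CSc2nnc(-c3cnccn3)n2-c2ccccc2)c(F)c1`) gives 10400 nM and lies within the scatter of both others (a 1.5-fold lower number from compound 2 to compound 3 (0.17 log units; within the scatter) and a 1.8-fold lower number from compound 1 to compound 3 (0.26 log units; within the scatter)). Compound 4 (`Fc1cccc(F)c1CSc1nnc(-c2cnccn2)n1-c1ccccc1`) has not been measured. It carries one change from compound 3 (2,6-difluorophenyl in place of 2,4-difluorophenyl on a saturated chain carbon bound to a sulfur) that joins the same atoms differently, placing 2,6-difluorophenyl on a saturated chain carbon bound to a sulfur. All three measured steps touch that same place. The closest parallel is the swap of 2-chlorophenyl for 4-chlorophenyl (a 1.2-fold lower number from compound 1 to compound 2 (0.09 log units; within the scatter)), which stays within the scatter like the other two. No step beyond the scatter is therefore expected here, though none of these compounds carries the 2,6-difluorophenyl group. The expected step is small (a 1.3-fold higher number from compound 3 to compound 4 (0.10 log units; within the scatter)) and within the scatter. Compound 4 is estimated at 13000 nM with an expected range from 6500 nM to 26000 nM in this test.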

Compound 4, half-maximal inhibitory concentration: 22600 nM
Estimate against measurement, compound 4: 1.7-fold (0.24 log units) below; the range from low to high includes it.
By their numbers in this assay, from the lowest: compounds 3, 2, 1 and 4 (each within the scatter of the next, the first and the last beyond it).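

In this assay, the swap of 2,4-difluorophenyl for 2,6-difluorophenyl on a saturated chain carbon bound to a sulfur gives a 2.2-fold higher number from compound 3 to compound 4 (0.34 log units; beyond the scatter), the only step at this place among the compounds shown that lies beyond the scatter, and it is modest, with the same atoms joined differently. Compound 4 still stays within the scatter of both chlorophenyl compounds, with a 1.5-fold higher number from compound 2 to compound 4 (0.17 log units; within the scatter) and a 1.2-fold higher number from compound 1 to compound 4 (0.08 log units; within the scatter), so at this place only compound 3 and compound 4 can be told apart. No available evidence bears on why these two difluorophenyl groups differ.

The compounds shown leave open whether 2,6-dichlorophenyl or plain phenyl at this place would read closer to compound 3 or to compound 4. They also leave open how a longer chain in place of the benzyl would read in this test.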